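Nitro to Cyano on the Sulfonyl Aryl Group

This account rests on a few compounds, and the source may have more. Where it says the series, first, only, none or still open, it means among the compounds named here.

The series shares one core, seen in compound 1 `COc1ccc(-c2cc(=O)c3c(OC)cc(OC)cc3[nH]2)cc1`. In a functional assay on SUP-B15 cells (Homo sapiens) for antiproliferative activity, with a stated time of 72 h (on this read-out higher numbers stand for an effect only at larger amounts of compound and lower numbers for an effect already at smaller amounts), compound 1 reaches only a limit of the assay, > 62000 nM. Compound 2 `COc1ccc(-c2cc(=O)c3c(OC)cc(OC)cc3n2C)cc1` carries a methyl on the aromatic nitrogen, and in this assay compound 2 gives 28000 nM; the step of an at least 2.2-fold lower number from compound 1 to compound 2 (0.34 log units; beyond the scatter) is beyond the scatter. Compound 3 `COc1ccc(-c2cc(=O)c3c(OC)cc(OC)cc3n2S(=O)(=O)c2ccc([N+](=O)[O-])cc2)cc1` bears a 4-nitrophenylsulfonyl group on that nitrogen, and in this assay compound 3 gives 17100 nM. Of the two values that are not limits, compound 3 has the lower one, but its gap to compound 2 lies within the scatter, so the two cannot be set in order.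

Compound 4 `COc1ccc(-c2cc(=O)c3c(OC)cc(OC)cc3n2S(=O)(=O)c2ccc(C#N)cc2)cc1` differs from compound 3 in one place: cyano in place of nitro on an aromatic carbon. Among the measured compounds shown here, no measured step touches this part of the molecule; the only measured step, an at least 2.2-fold lower number from compound 1 to compound 2 (0.34 log units; beyond the scatter), concerns the aromatic nitrogen itself and gives no guide to an exchange on the 4-nitrophenyl group. The step of a 1.0-fold lower number from compound 3 to compound 4 (0.00 log units; within the scatter) is therefore expected to lie within the scatter, with no clear direction. For compound 4 the estimate in this assay is 17000 nM, with a range from 6000 nM to 50000 nM.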

Compound 4, half-maximal effective concentration: 7900 nM
The estimate for compound 4 lay 2.2-fold (0.33 log units) above the measured number; the range from low to high includes it.
By their numbers in this assay, from the lowest: compound 4; then compounds 3 and 2 (each within the scatter of the next). At a limit, above all of these: compound 1.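

In this assay, among the compounds shown here, the exchange of nitro for cyano gives a 2.2-fold lower number from compound 3 to compound 4 (0.34 log units; beyond the scatter), so the sulfonyl aryl group, which no earlier step touched, responds to a change on this aromatic carbon, para to a large group. Compound 2 and compound 3 could not be set in order, but with the 4-cyanophenyl group the sulfonyl series now separates from the methyl compound, with a 3.5-fold lower number from compound 2 to compound 4 (0.55 log units; beyond the scatter). The remaining step, an at least 7.8-fold lower number from compound 1 to compound 4 (0.89 log units; beyond the scatter), starts from a limit for compound 1 and not from a number, so it gives only a bound: the limit of > 62000 nM in this assay, at which 1 of the 4 values shown sits.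

The compounds shown do not tell what lies behind the step from nitro to cyano, and whether an amine, a carboxylic acid or a longer chain on this carbon would follow compound 4 or compound 3 remains open. As far as these compounds go, it is also open whether a methylsulfonyl group on the aromatic nitrogen, without the aryl ring, would come close to compound 4 at 7900 nM, or whether the 4-cyanophenyl group is needed for that number.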